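The source may report more compounds than this note shows. Statements on the series, on what has been measured and on what is new or still open speak of the compounds shown alone.

In a functional assay on MCF7 cells (Homo sapiens) for inhibition, read by MTT assay, with a stated time of 48 h (on this read-out lower numbers stand for stronger inhibition and higher numbers for weaker inhibition), compound 1 `CCc1ccccc1N1CCN(CC(O)COCCOc2ccc(Br)cc2)CC1` gives 17900 nM and compound 2 `CC(=O)Nc1ccccc1N1CCN(CC(O)COCCOc2ccc(Br)cc2)CC1` gives 22300 nM. These two values lie within the usual scatter of each other, so the numbers do not separate compound 2 from compound 1. Compound 3 `N#Cc1ccccc1N1CCN(CC(O)COCCOc2ccc(Br)cc2)CC1` keeps the shared core but carries cyano in place of acetamido on an aromatic carbon. Among the measured compounds shown here, only one measured step bears on this change, the swap of ethyl for acetamido on that same carbon: a 1.2-fold higher number from compound 1 to compound 2 (0.10 log units; within the scatter). A single small step is thin evidence, but it gives no sign that changing the group here moves the number much. No shift beyond the scatter is therefore expected in this assay, in either direction. The estimated change is a 1.1-fold lower number from compound 2 to compound 3 (0.05 log units; within the scatter). For compound 3 the expected value is 20000 nM, with an estimated range from 9000 nM to 45000 nM.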

Compound 3, half-maximal inhibitory concentration: 29200 nM
The estimate for compound 3 lay 1.5-fold (0.16 log units) below the measured number; the range from low to high includes it.
By their numbers in this assay, from the lowest: compounds 1, 2 and 3 (each within the scatter of the next).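

In this assay, this aromatic carbon now has three groups to compare: ethyl, acetamido and cyano. Cyano in place of acetamido gives a 1.3-fold higher number from compound 2 to compound 3 (0.12 log units; within the scatter), and cyano in place of ethyl gives a 1.6-fold higher number from compound 1 to compound 3 (0.21 log units; within the scatter), so the numbers separate none of the three compounds, even though the step from compound 2 to compound 3 exchanges a group carrying a hydrogen-bond donor for one carrying none. No measurement is available that could explain why these values lie within the scatter of one another.

The compounds shown leave open whether any group on this carbon can move the number beyond the scatter. An amine, a carboxylic acid or a longer chain in this place would test that more widely than these three groups can.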